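This account rests on a few compounds, and the source may have more. Where it says the series, first, only, none or still open, it means among the compounds named here.

Measured so far:
Compound 1, `O=C(O)[C@@H]1NCC=C[C@@H]1O`: 1.3%
Compound 2, `O=C(O)[C@H]1NC[C@H](O)[C@@H](O)[C@H]1O`: 31%
Compound 3, `O=C(O)[C@H]1NC[C@@H](O)[C@H](O)[C@@H]1O`: 11%

In an assay for inhibition of alpha-N-acetylgalactosaminidase (Gallus gallus), tested at 1000 uM (on this read-out lower numbers stand for less inhibition and higher numbers for more inhibition at the one concentration tested (going by the name of the read-out)), compound 2 gives 31% and compound 3 gives 11%. Compound 1 lies below both: its gap to compound 2 is beyond the scatter, while its gap to compound 3 is within it, so compound 1 and compound 3 cannot be told apart on these numbers.

Compound 4, `O=C(O)[C@H]1NCC=C[C@@H]1O`, is not yet measured. It differs from compound 1 only in this way: the two compounds have the same atoms and bonds and differ only in configuration as drawn: 1 of 2 stereo elements differ; a stereocentre at a saturated ring carbon is drawn R in compound 1 and S in compound 4. Among the compounds with values here, the one measured step that concerns configuration alone is a number 20 percentage points lower from compound 2 to compound 3 (beyond the scatter), which shows that changing how the ring carbons are drawn can move the read-out by a modest amount, a point supported by the fact that compounds 2 and 3 differ only in the configuration as drawn. That step, however, involves three stereocentres, not one, and it runs from a higher starting number. Compound 1 already sits close to the bottom of the scale, so a drop of similar size is hardly possible; a rise of modest size, or no change beyond the scatter, are the remaining options. Compound 4 is therefore expected to give about 8%, with the likely range from 0% to 25%, a step of a number 6.7 percentage points higher from compound 1 to compound 4 (within the scatter).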

Compound 4, a percentage reported as inhibition, at one concentration (the size of the read-out at that concentration, not a potency): 25%
Compound 4: middle estimate off by 17 percentage points, on the low side; the range from low to high includes it.
By their numbers in this assay, from the lowest: compounds 1 and 3 (each within the scatter of the next); then compounds 4 and 2 (each within the scatter of the next).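

In this assay, a change at one stereocentre is enough to move the result clearly: the read-out is a number 23.7 percentage points higher from compound 1 to compound 4 (beyond the scatter). The earlier configuration step, a number 20 percentage points lower from compound 2 to compound 3 (beyond the scatter), changed three stereo elements at once, so it could not show whether any single one mattered, whereas here only one stereocentre at a saturated ring carbon goes from R to S while the other stays as drawn. The shift can be tied to that one stereocentre, since nothing else separates the pair: the fact that compounds 1 and 4 differ only in the configuration as drawn

Still open, from the compounds shown here alone, is what the other stereocentre of this pair contributes, since it keeps the same drawing in compound 1 and compound 4, and whether the preference for S at the changed carbon would hold on a different core. Also open is whether the preference survives a change of group, such as a methyl ester in place of the carboxylic acid or a benzyl group on the amine, and how any of these compounds behave at concentrations other than the single one tested.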